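This account rests on a few compounds, and the source may have more. Where it says the series, first, only, none or still open, it means among the compounds named here.

Cell toxicity is a useful early check on a compound series, since it shows how much compound is needed before cells begin to suffer. In an ADME assay on TERT-RPE1 cells (Homo sapiens) for cytotoxicity, read by MTT assay, with a stated time of 72 h (on this read-out higher numbers stand for weaker inhibition and lower numbers for stronger inhibition), compound 1 (`C=CC/N=C1\S/C(=C\c2ccc(OC)cc2)C(=O)N1C`) gives > 100000 nM. That value is a limit of the assay, not a number. Compound 1 therefore has no exact position on the scale, and no effect strong enough to reach a half-maximal reading was recorded for it. Within the data shown here, the only true number so far comes from compound 2 (`COc1ccc(/C=C2/CN(C)/C(=N/c3ccc(F)cc3)S2)cc1`), which gives 42800 nM in this assay.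

The next compound to be tested is compound 3 (`COc1ccc(/C=C2\S/C(=N\c3ccc(F)cc3)N(C)C2=O)cc1`). It has 4-fluorophenyl in place of allyl on a double-bonded nitrogen. Among the measured compounds shown here, the change adds an aromatic ring, but no measured step yet shows what such a swap does here. For the measured compounds named here, with compound 2 at 42800 nM as the only guide to scale, a modest move towards stronger inhibition is expected, estimated as an at least 2.0-fold lower number from compound 1 to compound 3 (0.30 log units; that floor lies within the scatter). A result that again reaches the limit would be no surprise. For compound 3, the expected value is 50000 nM, with an estimated range from 15000 nM to 100000 nM.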

Compound 3, half-maximal inhibitory concentration: > 100000 nM
Compound 3: only a limit was reported; the forecaster's own chance of this, stated with the estimate: 40%; middle value at least 2.0-fold (0.30 log units) from the limit.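

No step can be read from compound 1 to compound 3, because each gives only a limit and not a number: the limit of > 100000 nM in this assay, at which 2 of the 3 values shown sit.

As far as these compounds go, whether 4-fluorophenyl in place of allyl on a double-bonded nitrogen changes the toxicity to these cells at all remains open, and so does how the two compounds compare.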